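Pyrimidinyl Replaces Ethyl on a Piperazine Nitrogen

This account rests on a few compounds, and the source may have more. Where it says the series, first, only, none or still open, it means among the compounds named here.

Compound 1 `CCN(C)C(=S)SCC(O)Cn1c([N+](=O)[O-])cnc1C` and compound 2 `CCN1CCN(CC(O)Cn2c([N+](=O)[O-])cnc2C)CC1` share a common core and were both tested in a toxicity assay on HeLa cells (Homo sapiens) for cytotoxicity, read by MTT assay, with a stated time of 24 h; on this read-out lower numbers stand for stronger inhibition and higher numbers for weaker inhibition. In this assay compound 1 gives 4150000 nM. In this assay compound 2 gives 4940000 nM. Both numbers are very large, which means neither compound harms the cells to any marked degree, and compound 2 stands together with compound 1, since the gap between the two numbers lies within the usual scatter of such measurements. Compound 3 `Cc1ncc([N+](=O)[O-])n1CC(O)CN1CCN(c2ncccn2)CC1` has not yet been measured. It differs from compound 2 by pyrimidin-2-yl in place of ethyl on an amine nitrogen in a ring. Among the measured compounds shown here, no measured pair shows what such a change does here, so the expectation rests on the two numbers alone, both of which sit in the same weakly cytotoxic region; the step from compound 2 to compound 3 is therefore expected to be a 1.2-fold lower number from compound 2 to compound 3 (0.09 log units; within the scatter), with no shift beyond the scatter. For compound 3 in this assay the estimated value is 4000000 nM, with a range from 1500000 nM to 10000000 nM.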

Compound 3, half-maximal inhibitory concentration: 3930000 nM
Compound 3: middle estimate off by 1.0-fold (0.01 log units), on the high side; the range from low to high includes it.
By their numbers in this assay, from the lowest: compounds 3, 1 and 2 (each within the scatter of the next).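

In this assay, pyrimidin-2-yl in place of ethyl on the ring amine nitrogen gives a 1.3-fold lower number from compound 2 to compound 3 (0.10 log units; within the scatter), so compound 2 and compound 3 cannot be told apart. Among the compounds shown here, this pair is the first direct test of this position, and it shows that a group of 6 heavy atoms with one six-membered aromatic ring and 2 hydrogen-bond acceptors can replace an ethyl of 2 heavy atoms without a shift beyond the scatter, leaving the compound in the same weakly cytotoxic region. Nothing available explains why the number holds steady across this change.

A phenyl ring at this nitrogen would show whether the ring nitrogens of pyrimidin-2-yl matter to this result. A longer chain ending in a carboxylic acid or an amine remains an open test of how far this position stays so undemanding.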